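The source may hold more compounds than are shown below. What is called first, only, known or untested is meant among the compounds shown, and "the series" means these compounds.

In an assay on cells (blood) for antagonist activity at C-C chemokine receptor type 4 (Homo sapiens), read by flow cytometry (a higher number here means weaker binding, a lower number tighter binding), compound 2, whose structure is `COc1cc2[nH]c(=O)[nH]c2cc1NS(=O)(=O)c1cccc(Cl)c1Cl`, gives 5010 nM. This is the only actual number among the results shown; the other result is a limit. Compound 1, with structure `COc1cccc2c1c(NS(=O)(=O)c1cccc(Cl)c1Cl)nn2C`, gives > 10000 nM in this assay, which is a limit of the assay rather than a number, as noted in the limit of > 10000 nM in this assay, at which 1 of the 2 values shown sits. Compound 3, with structure `COc1cc2c(cc1NS(=O)(=O)c1cccc(Cl)c1Cl)[nH]c(=O)n2C`, has not yet been measured. It differs from compound 2 in a single place: methyl in place of hydrogen on an aromatic nitrogen. Going by the values given here, no measured pair of compounds differs in exactly this way, so the size of such a step cannot be read from the data. The change is small, and a step no larger than the usual scatter, in either direction, seems the likeliest expectation. The estimate for compound 3 in this assay is 5000 nM, with a range from 1500 nM to 16000 nM. The step this estimate implies is a 1.0-fold lower number from compound 2 to compound 3 (0.00 log units; within the scatter), essentially none beyond the scatter.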

Compound 3, dissociation constant: > 10000 nM
Compound 3 gave a limit, no number; the forecaster's own chance of this, stated with the estimate: 35%; at least 2.0-fold (0.30 log units) between middle value and limit.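

Going by these compounds alone, this is the first readable step at this position: methyl in place of hydrogen on an aromatic nitrogen gives an at least 1.9-fold higher number from compound 2 to compound 3 (0.30 log units; that floor lies within the scatter) in this assay. The added methyl brings no tighter binding here, although the step is only a floor and cannot show how much binding is lost. The result for compound 3 is a limit and not a number: the limit of > 10000 nM in this assay, at which 2 of the 3 values shown sit.

On these data alone, how far compound 3 really lies from compound 2 remains open, so this single change cannot yet be given a size. Also open, as far as these compounds go, is how this nitrogen would respond to something other than hydrogen or methyl, such as an ethyl group, a longer chain, or a chain ending in an amine or a carboxylic acid.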